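Trifluoromethyl in place of hydrogen on the unsubstituted core

This account rests on a few compounds, and the source may have more. Where it says the series, first, only, none or still open, it means among the compounds named here.

Measured compounds:
compound 1 `N=C(Nc1cccc(C(F)(F)F)c1)c1cc2c(-c3ccccc3)n[nH]c2cn1`: 19900 nM
compound 2 `N=C(Nc1ccccc1)c1cc2cn[nH]c2cn1`: "not determined" (no result reported)
compound 3 `N=C(Nc1ccccc1)c1cc2c(-c3ccccc3)n[nH]c2cn1`: 23000 nM

The account follows the step from compound 2 to compound 4 `N=C(Nc1cccc(C(F)(F)F)c1)c1cc2cn[nH]c2cn1`. In a functional assay on PC-3 cells (Homo sapiens) for cytotoxicity, read by MTT assay, with a stated time of 72 h (a lower number here means a stronger inhibitor, a higher number a weaker inhibitor), compound 2 has no number at all, so its standing among the measured compounds cannot be given. The change is trifluoromethyl in place of hydrogen on an aromatic carbon. For the measured compounds named here, only one measured step bears on it, run in the opposite sense on the core that carries a phenyl group: a 1.2-fold higher number from compound 1 to compound 3 (0.06 log units; within the scatter). That step lay within the scatter, so no movement beyond the scatter is expected from compound 2 to compound 4 in this assay. Because compound 1 gives 19900 nM and compound 3 gives 23000 nM, compound 4 is expected near that level, at an estimated 22000 nM in this assay, within 6000 nM to 80000 nM.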

Compound 4, half-maximal inhibitory concentration: > 50000 nM
Compound 4 gave a limit, no number (the forecaster's own chance of this, stated with the estimate: 25%); middle value at least 2.2-fold (0.35 log units) from the limit.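

In this assay, the shared core without its phenyl group, with trifluoromethyl kept, gave an at least 2.5-fold higher number from compound 1 to compound 4 (0.40 log units; beyond the scatter). Compound 4 reads only as a limit of the assay: the limit of > 50000 nM in this assay, at which 1 of the 4 values shown sits. The phenyl group thus matters here in a way the trifluoromethyl change on the core of compound 1 did not, as that step lay within the scatter.

The step from compound 2 to compound 4 cannot be read, and trifluoromethyl on the core without phenyl remains unresolved. Going by these compounds, whether an amine or a carboxylic acid on the phenyl group would shift the number also stays open.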